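Bromo Substitution and Adenosine A2b Antagonism

This account rests on a few compounds, and the source may have more. Where it says the series, first, only, none or still open, it means among the compounds named here.

Compound 1 `CCCn1cnc2c(NCc3ccccc3)ncnc21` and compound 2 `CCCn1cnc2c(NCCCc3ccccc3)ncnc21` share a core; the difference between the two cores is not broken down here. In a functional assay on CHO cells for antagonist activity at adenosine receptor A2b (Homo sapiens) (on this read-out lower numbers stand for stronger inhibition and higher numbers for weaker inhibition), compound 1 gives only a limit, > 30000 nM. Compound 2 likewise gives only a limit in this assay, > 30000 nM. Compound 3 `CCCn1c(Br)nc2c(NCc3ccccc3)ncnc21` carries the change bromo in place of hydrogen on an aromatic carbon and gives 7490 nM in this assay, so that an at least 4.0-fold lower number from compound 1 to compound 3 (0.60 log units; beyond the scatter). Two of the three values sit at the limit of > 30000 nM in this assay, at which 2 of the 3 values shown sit. Compound 4 `CCCn1c(Br)nc2c(NCCCc3ccccc3)ncnc21` has not been measured and carries the same change, (bromo in place of hydrogen on an aromatic carbon). Because an at least 4.0-fold lower number from compound 1 to compound 3 (0.60 log units; beyond the scatter), a step of similar size is expected for compound 4, although compound 2 itself is known only as a limit. Compound 4 is therefore estimated at 10000 nM, expected between 3000 nM and 30000 nM. That estimate means an at least 3.0-fold lower number from compound 2 to compound 4 (0.47 log units; beyond the scatter) is expected.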

Compound 4, inhibition constant: 1760 nM
Estimate against measurement, compound 4: 5.7-fold (0.75 log units) above, and the stated range ends above it.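

Carried to the second core, bromo in place of hydrogen on an aromatic carbon gives an at least 17-fold lower number from compound 2 to compound 4 (1.23 log units; beyond the scatter) in this assay. The change thus lowers the number on both cores shown, and no compound here goes against that, but this does not establish that the step has the same size on each core: the same change on two cores in this assay, an at least 4.0-fold lower number (0.60 log units; beyond the scatter) from compound 1 to compound 3 and an at least 17-fold lower number (1.23 log units; beyond the scatter) from compound 2 to compound 4; the limit leaves it open whether they differ Compound 1 and compound 2 are each known only as a limit, so neither step can be given an exact size: the limit of > 30000 nM in this assay, at which 2 of the 4 values shown sit.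

The compounds shown leave open whether chloro, iodo or methyl in the same place would act as bromo does. They also leave open whether the step would hold with a chain longer than propyl on the ring nitrogen.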